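Amino for hydroxy on a side ring: estimating compound 4

The source may hold more compounds than are shown below. What is called first, only, known or untested is meant among the compounds shown, and "the series" means these compounds.

Compound 1, `CCCS(=O)(=O)Nc1ccc(F)c(C(=O)c2n[nH]c3ncc(-c4ccc(F)cc4)cc23)c1F`: 2.1% in an assay for binding affinity to dual specificity mitogen-activated protein kinase kinase 4 (Homo sapiens), read by KINOMEscan, tested at 100 nM; on this read-out higher numbers stand for a weaker effect at the one concentration tested and lower numbers for a stronger effect
Compound 2, `CCCS(=O)(=O)Nc1ccc(F)c(C(=O)c2n[nH]c3ncc(-c4ccc(OC)cc4)cc23)c1F`: 4.2% in this assay
Compound 3, `CCCS(=O)(=O)Nc1ccc(F)c(C(=O)c2n[nH]c3ncc(-c4cccc(O)c4)cc23)c1F`: 2.2% in this assay

All three share one core and differ only in the aromatic group carried on it. Compound 3 stands second highest of the three numbers, but the step of a number 0.1 percentage points higher from compound 1 to compound 3 (within the scatter) and the step of a number 2 percentage points lower from compound 2 to compound 3 (within the scatter) are both within the scatter, so the three compounds cannot be told apart in this assay.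

Compound 4, `CCCS(=O)(=O)Nc1ccc(F)c(C(=O)c2n[nH]c3ncc(-c4cccc(N)c4)cc23)c1F`, has not yet been measured. It differs from compound 3 by one change: amino in place of hydroxy on an aromatic carbon.

Within the data shown here, the steps that bear on this are those in which the side ring was varied: a number 2.1 percentage points higher from compound 1 to compound 2 (within the scatter) and a number 2 percentage points lower from compound 2 to compound 3 (within the scatter). Neither of these changes moved the number beyond the scatter. On that basis the expected step of a number 0.8 percentage points higher from compound 3 to compound 4 (within the scatter) is none beyond the scatter in this assay. Compound 4 is therefore estimated at 3%, within a range from 1% to 10%.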

Compound 4, a percentage reported as activity, at one concentration (the size of the read-out at that concentration, not a potency): 1.6%
Compound 4: the middle estimate sits 1.4 percentage points above what was measured; measured number inside the range.
By their numbers in this assay, from the lowest: compounds 4, 1, 3 and 2 (each within the scatter of the next).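

In this assay, amino in place of hydroxy gives a number 0.6 percentage points lower from compound 3 to compound 4 (within the scatter), so this change on the side ring does not separate the two compounds. The wider changes of side ring agree: they give a number 2.6 percentage points lower from compound 2 to compound 4 (within the scatter) and a number 0.5 percentage points lower from compound 1 to compound 4 (within the scatter), which adds 3-aminophenyl to the groups that cannot be told apart here, alongside 3-hydroxyphenyl, 4-fluorophenyl and 4-methoxyphenyl. Nothing available here bears on why the number stays within the scatter across these four side rings.

The compounds leave open whether any group on this side ring can move the number beyond the scatter, such as a carboxylic acid or a morpholine. They also leave open whether these four compounds, alike at the one concentration tested, would show a stronger or weaker effect than one another at other concentrations.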